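Oxazole to Pyrazine: Expected Effect on Compound 4

A few compounds are considered here, and "the series" means these few. Any claim that something is new, unique, unknown or untested is made for them only; others in the source may bear on it.

Three compounds have been measured in a functional assay on CHO-K1 cells for antagonist activity at adenosine receptor A1 (Homo sapiens), read by a beta-galactosidase reporter and cAMP accumulation, with stated times of 15 min and 6 h; on this read-out higher numbers stand for weaker inhibition and lower numbers for stronger inhibition:
compound 1 `Cc1ccc(-c2nc(N)c3cc(Cc4ccccc4Cl)sc3n2)o1`, with 26.1 nM;
compound 2 `Nc1nc(-c2ncco2)nc2sc(Cc3ccccc3)cc12`, with 310 nM;
compound 3 `N#Cc1cccc(-c2nc(N)c3cc(Cc4ccccc4Cl)sc3n2)c1`, with 24.8 nM.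

Compound 2 gives the highest of the three numbers, the weakest inhibition; its gaps to compound 1 and to compound 3 both lie beyond the scatter. Compound 4 `Nc1nc(-c2cnccn2)nc2sc(Cc3ccccc3)cc12` differs from compound 2 in one place: pyrazin-2-yl in place of 1,3-oxazol-2-yl on an aromatic carbon. For the measured compounds named here, only one measured step exists, a 1.1-fold lower number from compound 1 to compound 3 (0.02 log units; within the scatter), which also exchanges one aromatic ring for another at that place of the shared core, though on a core carrying a different side chain. Going by the values given here, no step replaces 1,3-oxazol-2-yl itself. I therefore expect no step beyond the scatter, with a wide range. Compound 4 is expected to give 300 nM, between 100 nM and 900 nM. That estimate means a 1.0-fold lower number from compound 2 to compound 4 (0.01 log units; within the scatter).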

Compound 4, inhibition constant: 91 nM
Compound 4: middle estimate off by 3.3-fold (0.52 log units), on the high side, and the stated range ends above it.
By their numbers in this assay, from the lowest: compounds 3 and 1 (each within the scatter of the next); then compound 4; then compound 2.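

With the side chain and the rest of the core unchanged, exchanging 1,3-oxazol-2-yl for pyrazin-2-yl gives a 3.4-fold lower number from compound 2 to compound 4 (0.53 log units; beyond the scatter) in this assay. Unlike a 1.1-fold lower number from compound 1 to compound 3 (0.02 log units; within the scatter), this step shows that the choice of aromatic ring on this carbon can shift the number by more than the scatter, although only modestly. Nothing available explains this shift.

Going by these compounds, whether pyrazin-2-yl would give a similar step on the core of compound 1 remains open. So does what an amine or a carboxylic acid would give on this aromatic carbon.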